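A Second Methyl on the Saturated Ring of Lactam Inhibitors

The source may report more compounds than this note shows. Statements on the series, on what has been measured and on what is new or still open speak of the compounds shown alone.

Compound 1: `Cc1c(C2CCSCC2)c(=O)on1C(=O)N1CCCCC1`, 11 nM
Compound 2: `Cc1c(C(C)C)c(=O)on1C(=O)N1CCCCC1C`, 93 nM
Compound 3: `Cc1c(C2CCSCC2)c(=O)on1C(=O)N1CCC(C)CC1`, 6 nM

Three compounds were measured in an assay (strain Wistar) for inhibition of Hormone-sensitive lipase (Rattus norvegicus), read by spectrophotometry; on this read-out higher numbers stand for weaker inhibition and lower numbers for stronger inhibition. Compound 1 and compound 3 share the same core and differ by one change: methyl in place of hydrogen on a saturated ring carbon. The step of a 1.8-fold lower number from compound 1 to compound 3 (0.26 log units; within the scatter) is small. Compound 2 stands apart; how its core differs from that of compound 1 is not broken down here. In this assay compound 2 gives the highest number of the three, and compound 1 and compound 3 give lower numbers, both by more than the scatter.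

Compound 4, `Cc1c(C(C)C)c(=O)on1C(=O)N1CC(C)CCC1C`, has not yet been measured. It differs from compound 2 by methyl in place of hydrogen on a saturated ring carbon. This is the same kind of change as that from compound 1 to compound 3, but not the same: in compound 3 the methyl sits three ring bonds from the ring nitrogen and three from the ring atom that bears a large group, whereas in compound 4 it sits two ring bonds from the ring nitrogen, two from the ring atom that bears a large group, and three from the ring atom that bears a methyl group. On the strength of a 1.8-fold lower number from compound 1 to compound 3 (0.26 log units; within the scatter) alone, the step from compound 2 to compound 4 is expected to be a 1.3-fold lower number from compound 2 to compound 4 (0.12 log units; within the scatter), a small change that could well fall within the scatter. Compound 4 is therefore estimated at 70 nM, between 30 nM and 180 nM.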

Compound 4, half-maximal inhibitory concentration: 460 nM
For compound 4 the middle estimate is 6.6-fold (0.82 log units) below the measured one; measured number outside the range, above it.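

Set side by side in this assay, the two steps show that the effect of this methyl did not carry over from one core to the other: the same change on two cores in this assay, a 1.8-fold lower number (0.26 log units; within the scatter) from compound 1 to compound 3 and a 4.9-fold higher number (0.69 log units; beyond the scatter) from compound 2 to compound 4, 9.1-fold (0.96 log units) apart, beyond the scatter of two such steps On the core of compound 2 the new step is a 4.9-fold higher number from compound 2 to compound 4 (0.69 log units; beyond the scatter), which means weaker inhibition, whereas a 1.8-fold lower number from compound 1 to compound 3 (0.26 log units; within the scatter) is too small to count as a change in either direction. This does not show that the core alone sets the outcome, since the methyl also sits in a different place: three ring bonds from the ring nitrogen in compound 3, but two ring bonds from it in compound 4, where the ring already bears a methyl group, and one pair on each core cannot separate these differences.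

The compounds shown leave open whether a methyl three ring bonds from the ring nitrogen would be tolerated on the core of compound 2, and what a methyl two ring bonds from the ring nitrogen would do on the core of compound 1. They also leave open how an ethyl or a hydroxyl group on that same ring carbon would compare with the methyl on either core.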